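The source may hold more compounds than are shown below. What is called first, only, known or untested is meant among the compounds shown, and "the series" means these compounds.

Measured so far in a functional assay on NALM-6 cells (Homo sapiens) for cytotoxicity, read by luminescence and CellTiter-Glo, with a stated time of 3 days; a lower number here means a stronger inhibitor, a higher number a weaker inhibitor:
compound 1, `O=C(Nc1cc(C(F)(F)F)cc(C(F)(F)F)c1)c1ccc(-c2ccccc2)cc1O`: compound 1 gives 1580 nM
compound 2, `N#Cc1ccc(NC(=O)c2ccc3cccnc3c2O)cc1`: compound 2 gives 130 nM
compound 3, `N#Cc1ccc(NC(=O)c2ccc3cccnc3c2O)c(Cl)c1`: compound 3 gives 420 nM

Compound 2 and compound 3 share one core; compound 3 carries chloro in place of hydrogen on an aromatic carbon. That step is a 3.2-fold higher number from compound 2 to compound 3 (0.51 log units; beyond the scatter). Compound 1 stands on a different core, and the difference between the two cores is not broken down here. In this assay compound 1 gives the highest of the three numbers, its nearest neighbour being compound 3.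

Compound 4, `O=C(Nc1cc(C(F)(F)F)cc(C(F)(F)F)c1)c1cc(Cl)c(-c2ccccc2)cc1O`, is not yet measured. It differs from compound 1 by chloro in place of hydrogen on an aromatic carbon. Among the compounds with values here, this is the same kind of change as the one from compound 2 to compound 3, not the same: in compound 3 the chloro sits ortho to a large group and meta to a cyano group, whereas in compound 4 it sits ortho to a phenyl group, meta to a large group and para to a hydroxy group. Within the data shown here, the only guide is the single earlier instance on the other core, so the step from compound 1 to compound 4 is expected to be a 1.9-fold higher number from compound 1 to compound 4 (0.28 log units; within the scatter), weaker in size than and in the direction of a 3.2-fold higher number from compound 2 to compound 3 (0.51 log units; beyond the scatter). Compound 4 is estimated at 3000 nM, with a range from 1000 nM to 9000 nM.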

Compound 4, half-maximal inhibitory concentration: 560 nM
Beside the measured number, compound 4's estimate is 5.4-fold (0.73 log units) above it; the measured number lies below the stated range.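

In this assay, chloro in place of hydrogen on an aromatic carbon ortho to a phenyl group and para to a hydroxy group gives a 2.8-fold lower number from compound 1 to compound 4 (0.45 log units; beyond the scatter). The change does not carry from one core to the other with its direction intact: the same change on two cores in this assay, a 3.2-fold higher number (0.51 log units; beyond the scatter) from compound 2 to compound 3 and a 2.8-fold lower number (0.45 log units; beyond the scatter) from compound 1 to compound 4, 9.1-fold (0.96 log units) apart, beyond the scatter of two such steps. With a single pair on each core and the chloro at a different place in each, these results do not separate the effect of the core from that of the place on the ring, and they give no rule for any further core.

From the compounds shown here alone, it remains open whether the lower number for compound 4 is specific to chloro or would also appear with a fluoro, methyl or methoxy group on the same carbon. Also open, going by these compounds, is how chloro would behave at other aromatic carbons of compound 1 and compound 2.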